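Amide to Urea on a Shared Pyrazole-Bearing Core

The source may report more compounds than this note shows. Statements on the series, on what has been measured and on what is new or still open speak of the compounds shown alone.

Measured so far in a functional assay on RPMI-8226 cells (Homo sapiens) for inhibition, read by sulforhodamine B assay, with a stated time of 48 h; a higher number here means a weaker inhibitor, a lower number a stronger inhibitor:
compound 1 `COc1cc(-c2nn(-c3cccc(NC(=O)c4cccc(C(F)(F)F)c4)c3)cc2-c2ccncc2)ccc1Cl`: 1570 nM
compound 2 `O=C(Nc1cccc(-n2cc(-c3ccncc3)c(-c3ccc(Cl)c(O)c3)n2)c1)Nc1cc(C(F)(F)F)cc(C(F)(F)F)c1`: 480 nM
compound 3 `O=C(Nc1cccc(-n2cc(-c3ccncc3)c(-c3ccc(Cl)c(O)c3)n2)c1)Nc1ccc(Cl)c(C(F)(F)F)c1`: 580 nM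

Compound 1 stands at the top of these three numbers. Its gap to compound 3 and its gap to compound 2 both lie beyond the usual scatter of this assay, so compound 1 is the weakest inhibitor of the three measured compounds.

Compound 4 `COc1cc(-c2nn(-c3cccc(NC(=O)Nc4ccc(Cl)c(Cl)c4)c3)cc2-c2ccncc2)ccc1Cl` has not yet been measured. It keeps the core of compound 1 and changes only one place: (3,4-dichlorophenyl)amino in place of 3-(trifluoromethyl)phenyl on a carbonyl carbon. Among the compounds with values here, compound 2 and compound 3 also carry a carbamoyl linkage and both sit well below compound 1, but they differ from compound 1 in other places too, so no single step between measured compounds isolates this change. On that basis the account expects compound 4 to give a lower number than compound 1 in this assay, by a step beyond the scatter though not a large one, estimated as a 2.2-fold lower number from compound 1 to compound 4 (0.35 log units; beyond the scatter). For compound 4 the estimate is 700 nM, with a range from 300 nM to 1800 nM.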

Compound 4, half-maximal inhibitory concentration: 390 nM
Compound 4: middle estimate off by 1.8-fold (0.25 log units), on the high side; measured number inside the range.
By their numbers in this assay, from the lowest: compounds 4, 2 and 3 (each within the scatter of the next); then compound 1.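

Within the data shown here, on the core of compound 1, (3,4-dichlorophenyl)amino in place of 3-(trifluoromethyl)phenyl on a carbonyl carbon gives, in this assay, a 4.0-fold lower number from compound 1 to compound 4 (0.60 log units; beyond the scatter) as the first step at this position that changes one place only. Compound 2 and compound 3 differ from compound 1 in other places too, whereas here the change from (3-(trifluoromethyl)phenyl)carbonyl to (3,4-dichlorophenyl)carbamoyl stands alone, and its size lies beyond the scatter. No measurement at hand bears on why the number falls.

This one change swaps both the ring's substituents and the link to the carbonyl carbon, so the compounds shown do not separate the two. A 3-(trifluoromethyl)phenylamino group or a 3,4-dichlorophenyl group on the same carbonyl carbon would be needed to tell which part carries the step.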